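A few compounds are considered here, and "the series" means these few. Any claim that something is new, unique, unknown or untested is made for them only; others in the source may bear on it.

Compound 1 `COc1ccc(-c2cc3ccccc3nc2/C=C/C(=O)c2c(OC)cccc2OC)cc1` gives 4520 nM in a functional assay on MCF7 cells (Homo sapiens) for antiproliferative activity, read by XTT assay, with a stated time of 72 h; a lower number here means a stronger inhibitor, a higher number a weaker inhibitor.
Compound 2 `COc1ccc(-c2cc3ccccc3nc2/C=C/C(=O)c2ccsc2)cc1` gives 6010 nM.
Compound 3 `COc1ccc(-c2cc3ccccc3nc2/C=C/C(=O)c2sccc2N)cc1` gives only a limit, > 10000 nM.

Compound 1 has the lowest of the two numbers, though the step of a 1.3-fold higher number from compound 1 to compound 2 (0.12 log units; within the scatter) lies within the scatter. Compound 3 sits at a limit of the assay, (the limit of > 10000 nM in this assay, at which 1 of the 3 values shown sits), so the step of an at least 2.2-fold higher number from compound 1 to compound 3 (0.34 log units; beyond the scatter) is known only as a floor.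

Compound 4 `COc1ccc(-c2cc3ccccc3nc2/C=C/C(=O)c2cnc(N)nc2C)cc1` differs from compound 1 in one place: 2-amino-4-methylpyrimidin-5-yl in place of 2,6-dimethoxyphenyl on a carbonyl carbon. The two measured steps that swap the same group, a 1.3-fold higher number from compound 1 to compound 2 (0.12 log units; within the scatter) and an at least 2.2-fold higher number from compound 1 to compound 3 (0.34 log units; beyond the scatter), gave no change or a modest rise in the number. The step of a 1.7-fold higher number from compound 1 to compound 4 (0.22 log units; within the scatter) is therefore expected to be a small rise, possibly within the scatter. Compound 4 is estimated at 7500 nM, with a range from 3000 nM to 20000 nM.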

Compound 4, half-maximal inhibitory concentration: > 10000 nM
Compound 4: a limit, no number; the forecaster's own chance of this, stated with the estimate: 30%; at least 1.3-fold (0.12 log units) between middle value and limit.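

Compound 4 joins compound 3 at the limit of the assay: the limit of > 10000 nM in this assay, at which 2 of the 4 values shown sit. At this position on the carbonyl carbon, a six-membered ring with 2 hetero atoms therefore gives an at least 2.2-fold higher number from compound 1 to compound 4 (0.34 log units; beyond the scatter), while the other readable step is an at least 1.6-fold higher number from compound 2 to compound 4 (0.22 log units; that floor lies within the scatter), and the step between compound 3 and compound 4 cannot be read. Among these four compounds, only the two groups carrying an amino group reach the limit, and no compound goes against that.

Going by these compounds, whether the amino group matters here remains open. A 4-methylpyrimidin-5-yl group without the amine, or a plain phenyl, would help to separate the amine from the ring.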